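Removing a chloro from the weakest of three chloromethylbenzyl purines

A few compounds are considered here, and "the series" means these few. Any claim that something is new, unique, unknown or untested is made for them only; others in the source may bear on it.

Measured compounds:
- compound 1 `ClCc1ccccc1Cn1cnc2c(Cl)ncnc21`: 2290 nM
- compound 2 `ClCc1ccc(Cn2cnc3nc(Cl)nc(Cl)c32)cc1`: 19100 nM
- compound 3 `ClCc1ccc(Cn2cnc3c(Cl)nc(Cl)nc32)cc1`: 2140 nM

In a functional assay on Hs-578T cells (Homo sapiens) for cytotoxicity, read by sulforhodamine B assay, with a stated time of 48 h (a lower number here means a stronger inhibitor of growth, a higher number a weaker inhibitor of growth), compound 2 stands highest of the three numbers. Its nearest neighbour is compound 1, whose number is lower by more than the usual scatter, and compound 3 lies further still, so compound 2 is the weakest growth inhibitor of the three on these data.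

Compound 4 `ClCc1ccc(Cn2cnc3ncnc(Cl)c32)cc1` has not yet been measured in this assay. It differs from compound 2 in one place: hydrogen in place of chloro on an aromatic carbon.

Among the measured compounds shown here, no step of this kind, a chloro replaced by hydrogen on the shared core, has been measured within this set, so the size and direction of the step must be judged from the spread of the three numbers alone. Compound 1 and compound 3 differ in their count of chloro groups on the core yet give numbers close to each other, while compound 2, carrying two chloro groups arranged differently, stands far higher. A move from compound 2 toward the range of compound 1 is therefore expected, with wide uncertainty: the estimated step is a 3.2-fold lower number from compound 2 to compound 4 (0.50 log units; beyond the scatter). Compound 4 is expected to give about 6000 nM in this assay, within a range from 1500 nM to 25000 nM.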

Compound 4, concentration for 50% growth inhibition: 1730 nM
Compound 4: middle estimate off by 3.5-fold (0.54 log units), on the high side; low and high end bracket the measured number.
By their numbers in this assay, from the lowest: compounds 4, 3 and 1 (each within the scatter of the next); then compound 2.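

In this assay, the chloro on the aromatic carbon between two ring nitrogen atoms proves to be a liability rather than a requirement: putting hydrogen in its place gives an 11-fold lower number from compound 2 to compound 4 (1.04 log units; beyond the scatter), a large step. Among the compounds shown here, this is the first measured single change on the shared core, and it shows that growth inhibition responds strongly at this position, even though the change removes only one chlorine atom and adds no ring, charge, hydrogen-bond donor or hydrogen-bond acceptor. Nothing given here accounts for the size of this step, so the reason for it remains unknown.

The compounds shown leave open whether any group at this carbon would lower the number as hydrogen does, or whether chloro alone carries the penalty; an amine, a methoxy group or a fluoro group there would separate those two readings. They also leave open what the remaining chloro contributes to compound 4, since no compound shown has hydrogen or an amine at that place while the rest of compound 4 stays unchanged.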